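Swapping the benzyl ester side chain for isobutyl

A few compounds are considered here, and "the series" means these few. Any claim that something is new, unique, unknown or untested is made for them only; others in the source may bear on it.

Of the compounds shown here, three sharing the same core have so far been tested in a functional assay on the whole organism (Tail, strain ICR) with Mus musculus as the target, in the tail flick test, with a stated time of 30 min, at a dose of 25 umol/kg by the oral route; a higher number here means a stronger effect of the compound at the dose given, a lower number a weaker effect. Compound 1 `CC(C)[C@H](NC(=O)CN(c1nc(Cl)nc2[nH]cnc12)C1CC1)C(=O)OCc1ccccc1` gives 33.4%, compound 2 `N=C(N)NCCC[C@H](NC(=O)CN(c1nc(Cl)nc2[nH]cnc12)C1CC1)C(=O)OCc1ccccc1` gives 23.2%, and compound 3 `O=C(CN(c1nc(Cl)nc2[nH]cnc12)C1CC1)N[C@@H](CCC(=O)OCc1ccccc1)C(=O)OCc1ccccc1` gives 52.8%. Compound 3 stands highest of the three, with a number 19.4 percentage points higher from compound 1 to compound 3 (beyond the scatter) and a number 29.6 percentage points higher from compound 2 to compound 3 (beyond the scatter). Compound 4 `CC(C)C[C@H](NC(=O)CN(c1nc(Cl)nc2[nH]cnc12)C1CC1)C(=O)OCc1ccccc1` has not yet been measured. It differs from compound 3 in one place: isopropyl in place of (benzyloxycarbonyl)methyl on a saturated chain carbon, two bonds along the chain from an amide-type nitrogen and a carbonyl carbon. The measured step that bears on this change is the one where the benzyl ester chain was brought in, a number 19.4 percentage points higher from compound 1 to compound 3 (beyond the scatter); compound 4 takes that chain out again, leaving isobutyl where compound 1 carries isopropyl. The step of a number 10.2 percentage points lower from compound 1 to compound 2 (beyond the scatter) concerns a different group and says little here. A fall of about the size seen between compound 1 and compound 3 is therefore expected, with the estimated step being a number 16.8 percentage points lower from compound 3 to compound 4 (beyond the scatter). Compound 4 is expected to give about 36%, within a range from 22% to 50%.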

Compound 4, a percentage reported as activity, at one dose (the size of the read-out at that dose, not a potency): 33.9%
Beside the measured number, compound 4's estimate is 2.1 percentage points above it; the range from low to high includes it.
By their numbers in this assay, from the lowest: compound 2; then compounds 1 and 4 (each within the scatter of the next); then compound 3.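

Isobutyl and isopropyl on the saturated chain carbon cannot be told apart in this assay, with a number 0.5 percentage points higher from compound 1 to compound 4 (within the scatter). The fall on removing the benzyl ester chain, a number 18.9 percentage points lower from compound 3 to compound 4 (beyond the scatter), therefore now holds against two alkyl groups, so the higher read-out of compound 3 does not rest on a comparison with isopropyl alone. The chain of compound 2 also stays apart from isobutyl, with a number 10.7 percentage points higher from compound 2 to compound 4 (beyond the scatter), just as it did from isopropyl.

No measurement shown offers an explanation for these steps. A free carboxylic acid in place of the benzyl ester, a primary amine or a longer unbranched alkyl chain at this carbon lies outside the compounds shown, so it stays open whether the ester or the length of the chain goes with the higher read-out.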